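Swapping 2-bromophenyl for 3-chlorophenyl

This account rests on a few compounds, and the source may have more. Where it says the series, first, only, none or still open, it means among the compounds named here.

In a functional assay on HL-60 cells (Homo sapiens) for antiproliferative activity, read by MTT assay, with a stated time of 72 h (on this read-out higher numbers stand for weaker inhibition and lower numbers for stronger inhibition), compound 1 `NC1=NC2(CCOCC2)N(OCCCOc2ccccc2)C(N)=N1` gives 2460 nM, compound 2 `COc1ccc(OCCCON2C(N)=NC(N)=NC23CCOCC3)cc1` gives 1670 nM, and compound 3 `NC1=NC2(CCOCC2)N(OCCCOc2ccccc2Br)C(N)=N1` gives 610 nM, the lowest of the three numbers. Compound 4 `NC1=NC2(CCOCC2)N(OCCCOc2cccc(Cl)c2)C(N)=N1` has 3-chlorophenyl in place of 2-bromophenyl on an oxygen on a saturated carbon. Methoxy in place of hydrogen gave a 1.5-fold lower number from compound 1 to compound 2 (0.17 log units; within the scatter). The closest measured step is bromo in place of hydrogen, which gave a 4.0-fold lower number from compound 1 to compound 3 (0.61 log units; beyond the scatter). Going by the values given here, no measured compound carries chloro, but compound 4 keeps a halogen, so no step beyond the scatter is expected in this assay. The estimated step is a 1.3-fold higher number from compound 3 to compound 4 (0.12 log units; within the scatter). For compound 4 the expected value is 800 nM, with an estimated range from 300 nM to 2000 nM.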

Compound 4, half-maximal inhibitory concentration: 520 nM
Estimate against measurement, compound 4: 1.5-fold (0.19 log units) above; the measured number falls inside the stated range.
By their numbers in this assay, from the lowest: compounds 4 and 3 (each within the scatter of the next); then compounds 2 and 1 (each within the scatter of the next).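

In this assay, the step to compound 4 shows that 3-chlorophenyl and 2-bromophenyl cannot be told apart (a 1.2-fold lower number from compound 3 to compound 4 (0.07 log units; within the scatter)). Both the halogen and its place on the ring change here, yet the lower number holds: chloro in place of hydrogen gives (a 4.7-fold lower number from compound 1 to compound 4 (0.67 log units; beyond the scatter)), and 3-chlorophenyl in place of 4-methoxyphenyl gives (a 3.2-fold lower number from compound 2 to compound 4 (0.51 log units; beyond the scatter)). No evidence is available to explain these differences. The compounds shown do not separate the halogen from its place on the ring. As far as these compounds go, how an amine on the phenyl ring or a longer chain would read also stays open.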